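Oxetan-3-yl to 3,3,3-trifluoropropyl: working notes

This account rests on a few compounds, and the source may have more. Where it says the series, first, only, none or still open, it means among the compounds named here.

Compound 3 `CC[C@@H]1C(=O)N(C)c2cnc(-n3ccnc3-c3ccc(F)cc3)nc2N1C1COC1` stands highest of the three measured compounds in an ADME assay on microsomes from liver (Mus musculus) for metabolic stability, with a stated time of 30 min, tested at 1 uM (a lower number here means that less of the compound is left, a higher number that more of the compound is left), at 74% remaining. Compound 1 `CC[C@@H]1C(=O)N(C)c2cnc(-n3ccnc3-c3ccc(F)cc3)nc2N1[C@H]1CCOC1` follows at 63% remaining, and compound 2 `CC[C@@H]1C(=O)N(C)c2cnc(-n3ccnc3-c3ccccc3)nc2N1C1CCCC1` is lowest at 0% remaining.

Compound 4 `CC[C@@H]1C(=O)N(C)c2cnc(-n3ccnc3-c3ccc(F)cc3)nc2N1CCC(F)(F)F` carries 3,3,3-trifluoropropyl in place of oxetan-3-yl, a change counted as 3,3,3-trifluoropropyl in place of oxetan-3-yl on a nitrogen on an aromatic ring in a ring on a nitrogen on an aromatic ring in a ring, next to the ring atom that bears an ethyl group.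

Going by the values given here, one measured step bears directly on this place: oxetan-3-yl in place of oxolan-3-yl gave a number 11 percentage points higher from compound 1 to compound 3 (beyond the scatter) as a modest step. The entering group holds no ring oxygen, and compound 2, which also lacks one at this place, reads 0% in this assay but differs in a second place too, so it serves only as a loose warning. Among the compounds with values here, no measured compound carries an open chain here, and the range has to stay wide.

A fall larger than the modest measured step is expected, and the estimated change is a number 24 percentage points lower from compound 3 to compound 4 (beyond the scatter) in this series. Compound 4 is expected at 50% within an estimated range of 22% to 76% remaining.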

Compound 4, percent of the compound remaining: 32%
The estimate for compound 4 lay 18 percentage points above the measured number; the measured number falls inside the stated range.
By their numbers in this assay, from the lowest: compound 2; then compound 4; then compound 1; then compound 3.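

In this assay, going by these compounds alone, the open chain 3,3,3-trifluoropropyl gives the first reading at this place without a ring or a ring oxygen in a comparison that changes only this group, and the result is a number 42 percentage points lower from compound 3 to compound 4 (beyond the scatter) and also a number 31 percentage points lower from compound 1 to compound 4 (beyond the scatter) in the same series. Both of these large steps exceed the modest step between the two ring ethers, a number 11 percentage points higher from compound 1 to compound 3 (beyond the scatter), so in these three compounds the exchange of either ring for the chain moves the percentage remaining further than the exchange of one ring for the other. Nothing at hand gives a reason for the fall.

The step to compound 4 removes the ring and the ring oxygen and brings in the fluorines all at once, so the compounds shown leave open which of these changes goes with the lower reading. A plain propyl chain, a 2-methoxyethyl chain or a cyclobutyl ring at this place, on the same core with the same 4-fluorophenyl group, would begin to separate these three changes.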